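Amide aryl swap at the weak end of the series

The source may report more compounds than this note shows. Statements on the series, on what has been measured and on what is new or still open speak of the compounds shown alone.

The three measured compounds share one core and differ only in the group on the carbonyl carbon of the amide. Within the data shown here, compound 1 `Cc1nc(C(=O)Nc2ccc(Cl)c(-c3nnc4c(Cl)cccn34)c2)cs1` carries a 2-methyl-1,3-thiazol-4-yl group and is the only member with a number: in a functional assay on HeLa cells (Homo sapiens) for antiproliferative activity, read by MTT assay, with a stated time of 72 h (on this read-out higher numbers stand for weaker inhibition and lower numbers for stronger inhibition), compound 1 gives 79800 nM. Compound 2 `Cc1cc(Cl)ccc1C(=O)Nc1ccc(Cl)c(-c2nnc3c(Cl)cccn23)c1` carries a 4-chloro-2-methylphenyl group; in this assay compound 2 reaches only the assay limit, > 100000 nM. Compound 3 `O=C(Nc1ccc(Cl)c(-c2nnc3c(Cl)cccn23)c1)c1ccon1` carries a 1,2-oxazol-3-yl group; in this assay compound 3 likewise ends at the limit, > 100000 nM. Compound 3 therefore sits at the top of the numbers shown, where two of the three values rest (the limit of > 100000 nM in this assay, at which 2 of the 3 values shown sit). The steps of an at least 1.2-fold higher number from compound 1 to compound 2 (0.09 log units; that floor lies within the scatter) and an at least 1.2-fold higher number from compound 1 to compound 3 (0.09 log units; that floor lies within the scatter) are floors only, and a step that the two limits leave unreadable from compound 2 to compound 3 cannot be read.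

Compound 4 `O=C(Nc1ccc(Cl)c(-c2nnc3c(Cl)cccn23)c1)c1ccccc1` is the next member; the change from compound 3 is phenyl in place of 1,2-oxazol-3-yl on a carbonyl carbon. Compound 2, whose carbonyl also carries a six-membered ring of carbon only, sits at the limit. Since an at least 1.2-fold higher number from compound 1 to compound 2 (0.09 log units; that floor lies within the scatter) and an at least 1.2-fold higher number from compound 1 to compound 3 (0.09 log units; that floor lies within the scatter) are floors within the scatter, the step of a number no higher from compound 3 to compound 4 (the limit leaves the size open) expected for compound 4 in this assay is none beyond the scatter, with a fair chance of a limit again. The estimate for compound 4 is 100000 nM, expected between 40000 nM and 300000 nM.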

Compound 4, half-maximal inhibitory concentration: > 100000 nM
Compound 4 gave a limit, no number; the forecaster's own chance of this, stated with the estimate: 60%; the middle value lies on the limit itself.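

In this assay the plain phenyl group joins the other groups at the limit, which shows that neither the hetero atoms of 1,2-oxazol-3-yl nor the chloro and methyl substituents of the 4-chloro-2-methylphenyl group of compound 2 are needed for a member of this series to end there. Among these compounds, the comparison with the only member that has a number gives an at least 1.2-fold higher number from compound 1 to compound 4 (0.09 log units; that floor lies within the scatter) and so supplies one more floor, which leaves compound 1 and its 2-methyl-1,3-thiazol-4-yl group without a demonstrated edge over any other group at this place. The steps among compound 2, compound 3 and compound 4 cannot be read, and the change on the carbonyl carbon has so far produced almost no measurable spread: the limit of > 100000 nM in this assay, at which 3 of the 4 values shown sit.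

As far as these compounds go, whether any group on this carbonyl carbon can bring the series clearly under the limit remains open, for example an aliphatic amine, a carboxylic acid or a longer alkyl chain. Also open is whether the methyl on the 1,3-thiazol-4-yl ring contributes to the single number in hand, since the unsubstituted 1,3-thiazol-4-yl group is not among the compounds shown.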